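The compounds below may be only part of what the source reports. "The series", "measured", "known", "first", "only" and "open" are said of these compounds alone.

Measured so far:
compound 1 `CC(C)(C)c1ccc(CN2CCN(C(=O)CCc3cc(-c4ccc(F)cc4)n(-c4ccc(Cl)cc4)n3)CC2)cc1`, with 2600 nM in an assay on isolated protein for inhibition of Polyunsaturated fatty acid 5-lipoxygenase (Homo sapiens), read by HPLC, with a stated time of 15 min, in the presence of a further agent that is not named here; on this read-out lower numbers stand for stronger inhibition and higher numbers for weaker inhibition
compound 2 `CC(C)(C)c1ccc(CN2CCN(C(=O)CCc3cc(-c4ccc(F)cc4)n(-c4ccc5ccccc5n4)n3)CC2)cc1`, with 2800 nM in this assay

On these numbers compound 2 and compound 1 sit within the scatter of each other: a 1.1-fold higher number from compound 1 to compound 2 (0.03 log units; within the scatter). Compound 3 `COc1ccc(-n2nc(CCC(=O)N3CCN(Cc4ccc(C(C)(C)C)cc4)CC3)cc2-c2ccc(F)cc2)nn1` differs from compound 2 by 6-methoxypyridazin-3-yl in place of quinolin-2-yl on an aromatic nitrogen. For the measured compounds named here, the only measured step at this aromatic nitrogen is a 1.1-fold higher number from compound 1 to compound 2 (0.03 log units; within the scatter), which moved nothing beyond the scatter; nothing measured speaks to a 6-methoxypyridazin-3-yl group here. In this assay compound 3 is therefore expected to change by a 1.3-fold higher number from compound 2 to compound 3 (0.10 log units; within the scatter), not beyond the scatter. Compound 3 is estimated at 3500 nM, range 1400 nM to 9000 nM.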

Compound 3, half-maximal inhibitory concentration: > 10000 nM
Compound 3 ended at the assay's limit (the forecaster's own chance of this, stated with the estimate: 5%); middle value at least 2.8-fold (0.45 log units) from the limit.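

Substituent choice on this aromatic nitrogen can matter: 6-methoxypyridazin-3-yl in place of quinolin-2-yl gives an at least 3.5-fold higher number from compound 2 to compound 3 (0.55 log units; beyond the scatter), and in place of 4-chlorophenyl gives an at least 3.8-fold higher number from compound 1 to compound 3 (0.58 log units; beyond the scatter). Quinolin-2-yl and 4-chlorophenyl had stayed within the scatter of each other, so this is the first step at the position that goes beyond it. The value of compound 3 is a limit and not a number, so the full size of both steps stays unread: the limit of > 10000 nM in this assay, at which 1 of the 3 values shown sits.

The compounds shown do not separate the methoxy group from the ring nitrogens of the pyridazine. Open, as far as these compounds go, is how a 4-methoxyphenyl group or an unsubstituted pyridazin-3-yl group would read at this nitrogen.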